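Swapping the hydroxypyridine of compound 2 for a pyrazine

The source may report more compounds than this note shows. Statements on the series, on what has been measured and on what is new or still open speak of the compounds shown alone.

Compound 1 `CCOc1cccc(-c2cc(F)ccc2[C@H]2Cc3nc(N)nc(C)c3C(=O)N2)n1` with the value 290 nM as measured
Compound 2 `Cc1nc(N)nc2c1C(=O)N[C@@H](c1ccc(F)cc1-c1cccc(O)n1)C2` with > 10000 nM as a limit of the assay, not a number

Both results come from a functional assay on GTL 16 cells (Homo sapiens) for cytotoxicity, with a stated time of 72 h; a higher number here means that more compound is needed for the effect, a lower number that less compound is needed. Compound 2 stands only at a limit (the limit of > 10000 nM in this assay, at which 1 of the 2 values shown sits), so it has no exact place on the scale.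

Within the data shown here, the one measured step, an at least 34-fold higher number from compound 1 to compound 2 (1.53 log units; beyond the scatter), puts hydrogen in place of the ethyl on the oxygen. It is large and beyond the scatter.

Compound 3 `COc1nc(-c2cc(F)ccc2[C@H]2Cc3nc(N)nc(C)c3C(=O)N2)cnc1C` now brings in 6-methoxy-5-methylpyrazin-2-yl in place of the 6-hydroxypyridin-2-yl of compound 2, on an aromatic carbon (6-methoxy-5-methylpyrazin-2-yl in place of 6-hydroxypyridin-2-yl on an aromatic carbon). The oxygen again carries a carbon group rather than hydrogen. Compound 1 has that feature too and reaches 290 nM in this assay, so a large step to a lower number is expected. Among the measured compounds shown here, the ring itself also changes, and no measured step covers that part, so the range stays wide. The expected step is an at least 33-fold lower number from compound 2 to compound 3 (1.52 log units; beyond the scatter), beyond the scatter. For compound 3 the estimated value is 300 nM (expected range 70 nM to 1300 nM).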

Compound 3, half-maximal effective concentration: 34 nM
Estimate against measurement, compound 3: 8.8-fold (0.95 log units) above; the measured number lies below the stated range.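

In this assay, the informative comparison is with the ethoxypyridine, where 6-methoxy-5-methylpyrazin-2-yl in place of 6-ethoxypyridin-2-yl gives an 8.5-fold lower number from compound 1 to compound 3 (0.93 log units; beyond the scatter). Compound 1 already carries a carbon group on the oxygen, so this modest step shows that the number at this position on the fluorinated ring also answers to a change in the aromatic ring and its substituents, not only to whether the oxygen carries hydrogen. Against the hydroxypyridine the same kind of swap gives an at least 290-fold lower number from compound 2 to compound 3 (2.46 log units; beyond the scatter), but that step has only a lower bound, as compound 2 stands at a limit of the assay and not at a number: the limit of > 10000 nM in this assay, at which 1 of the 3 values shown sits.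

Compound 1 and compound 3 differ at once in the ring, in the methoxy against the ethoxy group and in the added methyl, so the compounds shown cannot tell which of these changes carries the step. Going by these compounds, it also stays open how an amine on the pyrazine, or a chain longer than ethyl on the oxygen, would read in this assay.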